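A methyl step repeated on a second core

The source may hold more compounds than are shown below. What is called first, only, known or untested is meant among the compounds shown, and "the series" means these compounds.

compound 1, `COC(=O)/C=C/C(=O)c1ccccc1`, in a physicochemical assay for lipophilicity; on this read-out higher numbers stand for higher lipophilicity and lower numbers for lower lipophilicity: 2.24
compound 2, `COC(=O)/C=C/C(=O)c1ccc(C)cc1`, in this assay: 2.74
compound 3, `C/C(=C\C(=O)O)C(=O)c1ccccc1`, in this assay: 2.44

Compound 1 and compound 2 differ by methyl in place of hydrogen on an aromatic carbon, and that change gave a number 0.50 log units higher from compound 1 to compound 2 (beyond the scatter). Compound 3 has the same atoms as compound 1 joined differently; the difference between the two cores is not broken down here, and its values against compound 1 and compound 2 both fall within the scatter. Compound 4, `C/C(=C\C(=O)O)C(=O)c1ccc(C)cc1`, has not been measured. It differs from compound 3 by methyl in place of hydrogen on an aromatic carbon, the same change as from compound 1 to compound 2, with the same place. Because a number 0.50 log units higher from compound 1 to compound 2 (beyond the scatter) was seen on the first core, a step of similar size, a number 0.50 log units higher from compound 3 to compound 4 (beyond the scatter), is expected on the second. Compound 4 is therefore estimated at 2.94, between 2.6 and 3.3.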

Compound 4, partition coefficient: 2.94
Compound 4: the middle estimate sits on the measured number at the digits printed; low and high end bracket the measured number.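

In this assay methyl in place of hydrogen on an aromatic carbon gave a number 0.50 log units higher from compound 3 to compound 4 (beyond the scatter) on the second core, matching in size a number 0.50 log units higher from compound 1 to compound 2 (beyond the scatter) on the first. This shows that the step carried across these two cores, but it rests on one change at one place and does not show that the step would hold on any other core. Nothing measured here says why the two steps came out alike.

The compounds shown leave open whether an ethyl group, a longer chain or an amine at that place would also give steps of matching size on both cores. They also leave open how methyl would behave at another position on the ring.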